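Swapping methoxy for methylsulfanyl in a weakly cytotoxic series

The source may report more compounds than this note shows. Statements on the series, on what has been measured and on what is new or still open speak of the compounds shown alone.

Measured so far in a functional assay on CCRF-CEM cells (Homo sapiens) for cytotoxicity, read by MTT assay, with a stated time of 72 h; a higher number here means a weaker inhibitor of growth, a lower number a stronger inhibitor of growth:
compound 1 `COc1ccc(CNc2nc([Se]C)nc3ccccc23)cc1` gives > 100000 nM, a limit of the assay.
compound 2 `COc1ccc(CNc2nc(SC)nc3ccccc23)cc1` gives > 100000 nM, also a limit.
compound 3 `CSc1nc(NCc2ccccc2)c2cccnc2n1` gives 98600 nM.

Compound 1 therefore has no number of its own, only a limit, and the limit of > 100000 nM in this assay, at which 2 of the 3 values shown sit, shows how little the series has been resolved. Within the data shown here, the only one-place step, a step that the two limits leave unreadable from compound 1 to compound 2, concerns the core and is unreadable. Compound 4 `CSc1ccc(CNc2nc([Se]C)nc3ccccc23)cc1` differs from compound 1 by methylsulfanyl in place of methoxy on an aromatic carbon. Among the measured compounds shown here, no measured step touches this ring, so nothing points to a shift in either direction beyond the scatter in this assay. Compound 4 is expected to stay near the limit, estimated at 100000 nM within 40000 nM to 250000 nM. The expected step of a number no higher from compound 1 to compound 4 (the limit leaves the size open) is thus none beyond the scatter.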

Compound 4, concentration for total growth inhibition: 86900 nM
Estimate against measurement, compound 4: 1.2-fold (0.06 log units) above, within the range that was stated.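

On the ring that carries the methoxy group, this assay now shows an at least 1.1-fold lower number from compound 1 to compound 4 (0.06 log units; that floor lies within the scatter). Methylsulfanyl in place of methoxy, para to a large group, thus gives a readable number, yet nothing shows a change beyond the scatter. The true size of the step stays open because compound 1 has only a limit: the limit of > 100000 nM in this assay, at which 2 of the 4 values shown sit.

The compounds shown leave open whether an amine or a carboxylic acid at this position would move the number clearly away from the limit. Going by these compounds, a longer chain on the sulfur remains equally open.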